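A few compounds are considered here, and "the series" means these few. Any claim that something is new, unique, unknown or untested is made for them only; others in the source may bear on it.

Of the compounds shown here, three built on one shared core have been measured in an assay on mitochondria from L6 cells (Rattus norvegicus) for activation, with a stated time of 90 min; a higher number here means that more compound is needed for the effect, a lower number that less compound is needed. Compound 1, `Oc1nc2nonc2nc1Nc1ccc(OC(F)(F)F)c(Cl)c1`, gives 3000 nM. Compound 2, `Oc1nc2nonc2nc1Nc1cccc(S(F)(F)(F)(F)F)c1`, gives 3700 nM, the second highest of the three numbers; it lies within the usual scatter of the number for compound 1, so the two cannot be told apart on this measurement. Compound 3, `CC(=O)c1ccc(Nc2nc3nonc3nc2O)cc1`, gives 93700 nM, a number that sits far beyond the scatter from compound 2, so more of compound 3 is needed for the same effect.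

Compound 4, `Oc1nc2nonc2nc1Nc1cccc(C(F)(F)F)c1`, has not yet been measured. It differs from compound 2 in one place: a group of 4 heavy atoms (1 carbon, 3 fluorine; no ring) in place of a group of 6 heavy atoms (5 fluorine, 1 sulfur; no ring), on an aromatic carbon. For the measured compounds named here, no pair of measured compounds shows this exact exchange, so its effect has to be guessed. One fluorine-bearing group replaces another on the same aromatic carbon, and the step of a 1.2-fold higher number from compound 2 to compound 4 (0.09 log units; within the scatter) is expected to be small, a modest rise in the number that may well stay within the scatter. Compound 4 is therefore estimated at 4500 nM, with a likely range from 2000 nM to 12000 nM.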

Compound 4, half-maximal effective concentration: 13300 nM
The estimate for compound 4 lay 3.0-fold (0.47 log units) below the measured number; measured number outside the range, above it.
By their numbers in this assay, from the lowest: compounds 1 and 2 (each within the scatter of the next); then compound 4; then compound 3.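

In this assay, for the compounds shown here, trifluoromethyl in place of the group of 5 fluorine and 1 sulfur on this aromatic carbon gives a 3.6-fold higher number from compound 2 to compound 4 (0.56 log units; beyond the scatter) and is the first exchange here that can be read between two measured compounds. It shows that this position does not treat the two fluorine-bearing groups alike: with the group of fewer heavy atoms, more compound is needed for the same effect. Nothing measured on either group bears on this step, so no explanation for it can be offered.

Still open, from the compounds shown here alone, is how other groups on this aromatic carbon would compare, such as an amine, a carboxylic acid or a longer chain. Also open, going by these compounds, is whether the same exchange would give a step of similar size on a ring that also carries chlorine, as the ring in compound 1 does.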